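This account rests on a few compounds, and the source may have more. Where it says the series, first, only, none or still open, it means among the compounds named here.

Compound 1 `O=S(=O)(Nc1ccc(-c2nc3cc(NS(=O)(=O)c4ccccc4)ccc3o2)cc1)c1ccccc1` gives 80000 nM in this assay.
Compound 2 `O=S(=O)(Nc1ccc2oc(-c3ccccc3)nc2c1)c1ccccc1F` reaches only the limit > 100000 nM in this assay.
Compound 3 `O=S(=O)(Nc1ccc(-c2nc3cc(NS(=O)(=O)c4ccccc4F)ccc3o2)cc1)c1ccccc1F` gives 57000 nM in this assay.

All three share one core and carry at least one sulfonamide. In an assay on cells for inhibition of HSP60/HSP10 (Homo sapiens), with a stated time of 60 min (a lower number here means a stronger inhibitor, a higher number a weaker inhibitor), compound 1 gives 80000 nM and compound 3 gives 57000 nM; both numbers are weak. For compound 2 the read-out is a limit rather than a number, > 100000 nM, so its true position is known only from one side. Within the data shown here, the single step measured between neighbours, an at least 1.7-fold lower number from compound 2 to compound 3 (0.24 log units; that floor lies within the scatter), adds a second sulfonamide group and stays within the scatter; the limit of > 100000 nM in this assay, at which 1 of the 3 values shown sits, shows how thin the evidence on compound 2 is.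

Compound 4 `COc1ccc(S(=O)(=O)Nc2ccc3oc(-c4ccccc4)nc3c2)cc1` has not yet been measured. It differs from compound 2 in 4-methoxyphenyl in place of 2-fluorophenyl on a sulfonyl sulfur. No measured step exchanges the ring on the sulfonyl sulfur, so nothing shown bears directly on this swap; the only step in hand concerns a different change. A step no larger than the scatter is expected, a number no higher from compound 2 to compound 4 (the limit leaves the size open). Compound 4 is therefore estimated at 100000 nM, between 40000 nM and 250000 nM, with a fair chance that this assay again reports only a limit.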

Compound 4, half-maximal inhibitory concentration: > 100000 nM
Compound 4: no number, only a limit (the forecaster's own chance of this, stated with the estimate: 55%); the middle value sits exactly at the limit.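

The step between compound 2 and compound 4 cannot be read, since each ends at a limit rather than a number: the limit of > 100000 nM in this assay, at which 2 of the 4 values shown sit.

In this assay the compounds shown leave open whether 4-methoxyphenyl in place of 2-fluorophenyl on a sulfonyl sulfur changes inhibition at all.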